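A few compounds are considered here, and "the series" means these few. Any claim that something is new, unique, unknown or untested is made for them only; others in the source may bear on it.

Measured so far:
compound 1, `Cc1cccc(C#Cc2ccc3c(n2)CCN(C)C3=O)c1`, in a functional assay on HEK293 cells for negative allosteric modulation of metabotropic glutamate receptor 5 (Homo sapiens), read by FLIPR and calcium flux (a higher number here means a weaker inhibitor, a lower number a stronger inhibitor), gives 2.9 nM
compound 2, `Cc1ccc(C#Cc2ccc3c(n2)CCN(C)C3=O)cc1`, in this assay gives 1400 nM

Compound 2 stands at the higher of the two numbers; its nearest neighbour is compound 1, and the step of a 480-fold higher number from compound 1 to compound 2 (2.68 log units; beyond the scatter) is large. The unmeasured compound 3, `CN1CCc2nc(C#Cc3ccc(Cl)cc3)ccc2C1=O`, differs from compound 2 by chloro in place of methyl on an aromatic carbon. For the measured compounds named here, only one measured step touches this ring: the step of a 480-fold higher number from compound 1 to compound 2 (2.68 log units; beyond the scatter), which moved a methyl from one position to another rather than swapping one group for another at the same position. It shows that this ring matters greatly for this assay, but it does not show which way a chloro in place of a methyl would move the number. An exchange of one small group for another at the same position is therefore expected to give a step of modest size in either direction, a 1.8-fold lower number from compound 2 to compound 3 (0.24 log units; within the scatter). Compound 3 is estimated at 800 nM, with a range from 150 nM to 5000 nM.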

Compound 3, half-maximal inhibitory concentration: 352 nM
Beside the measured number, compound 3's estimate is 2.3-fold (0.36 log units) above it, within the range that was stated.
By their numbers in this assay, from the lowest: compound 1; then compound 3; then compound 2.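

For the compounds shown here, this is the first exchange of one group for another at a single position on this ring: in this assay the change from methyl to chloro, para to a large group, gives a 4.0-fold lower number from compound 2 to compound 3 (0.60 log units; beyond the scatter) and so shows that the identity of the group there affects the number, not only where a group sits. Chloro at this position still leaves a 120-fold higher number from compound 1 to compound 3 (2.08 log units; beyond the scatter) as the gap, but that step changes both the group and its position, so it cannot be divided between the two changes. Nothing available explains why chloro gives the lower number.

On these data alone, it remains open whether 3-chlorophenyl would give a number close to that of the 3-methylphenyl in compound 1. As far as these compounds go, how a methoxy group, an amine or a carboxylic acid para to the large group would read also remains open.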